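Shifting the hydroxyl: what to expect for compound 4

This account rests on a few compounds, and the source may have more. Where it says the series, first, only, none or still open, it means among the compounds named here.

Compound 1, `COc1ccccc1C1CCN(CC(=O)Nc2cccc(C)c2)CC1`: 420 nM
Compound 2, `Cc1cccc(NC(=O)CN2CCC(c3cccc(F)c3)CC2)c1`: 512 nM
Compound 3, `Cc1cccc(NC(=O)CN2CCC(c3ccc(O)cc3)CC2)c1`: 70 nM

All three were run in a functional assay on HEK293 cells for agonist activity at D(4) dopamine receptor (Homo sapiens), read by FLIPR; a lower number here means that less compound is needed, a higher number that more compound is needed for the effect. Compound 3 gives the lowest of the three numbers, set apart from both neighbours by a 6.0-fold lower number from compound 1 to compound 3 (0.78 log units; beyond the scatter) and a 7.3-fold lower number from compound 2 to compound 3 (0.86 log units; beyond the scatter). Compound 4, `Cc1cccc(NC(=O)CN2CCC(c3cccc(O)c3)CC2)c1`, keeps the same atoms of compound 3 joined differently: 3-hydroxyphenyl in place of 4-hydroxyphenyl on a saturated ring carbon. For the measured compounds named here, the steps that bear on this are the two leading to compound 3, which both show the 4-hydroxyphenyl group giving lower numbers than the 2-methoxyphenyl or 3-fluorophenyl groups; no measured pair moves a hydroxyl from one position to another. Part of the advantage seen in a 6.0-fold lower number from compound 1 to compound 3 (0.78 log units; beyond the scatter) is therefore expected to be lost, giving an expected 2.3-fold higher number from compound 3 to compound 4 (0.36 log units; beyond the scatter). Compound 4 is estimated at 160 nM, within 50 nM to 500 nM.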

Compound 4, half-maximal effective concentration: 8 nM
Compound 4: the middle estimate sits 20-fold (1.30 log units) above what was measured, outside the stated range (below it).
By their numbers in this assay, from the lowest: compound 4; then compound 3; then compounds 1 and 2 (each within the scatter of the next).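

In this assay, moving the hydroxyl alone gives an 8.8-fold lower number from compound 3 to compound 4 (0.94 log units; beyond the scatter), so where the hydroxyl sits on the aromatic ring counts, not only whether it is present. Hydroxy in place of fluoro on an aromatic carbon gives a 64-fold lower number from compound 2 to compound 4 (1.81 log units; beyond the scatter), and 3-hydroxyphenyl in place of 2-methoxyphenyl gives a 53-fold lower number from compound 1 to compound 4 (1.72 log units; beyond the scatter), both large steps. Nothing available explains why the place of the hydroxyl matters in this way. The compounds shown leave open how a 2-hydroxyphenyl group would compare. They also leave open whether an amine or a carboxylic acid could stand in for the hydroxyl.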